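The source may report more compounds than this note shows. Statements on the series, on what has been measured and on what is new or still open speak of the compounds shown alone.

Measured in a functional assay on SW-620 cells (Homo sapiens) for antiproliferative activity, read by MTT assay, with a stated time of 72 h; a higher number here means a weaker inhibitor, a lower number a stronger inhibitor:

Compound 1 `CCCCCCC#Cc1c(CCCCCC)oc2nc(=O)n(Cc3cn(-c4ccc(Cl)cc4)nn3)cc12`: > 100000 nM, a limit of the assay rather than a number.
Compound 2 `CCCCCCC#Cc1c(CCCCCC)oc2nc(=O)n(Cc3cn(Cc4ccccc4)nn3)cc12`: 32600 nM.
Compound 3 `O=c1nc2oc(C3CC3)cc2cn1Cc1cn(-c2ccc(Cl)cc2)nn1`: > 100000 nM, again a limit of the assay.

Compounds 1 and 2 share one core and differ only in benzyl in place of 4-chlorophenyl on an aromatic nitrogen. In this assay that change gave an at least 3.0-fold lower number from compound 1 to compound 2 (0.48 log units; beyond the scatter); the step is known only as a lower bound because the limit of > 100000 nM in this assay, at which 2 of the 3 values shown sit, is where compound 1 sits. Compound 3 carries a different core; the difference between the two cores is not broken down here. Compound 4 `O=c1nc2oc(C3CC3)cc2cn1Cc1cn(Cc2ccccc2)nn1` bears the same change as the first pair, (benzyl in place of 4-chlorophenyl on an aromatic nitrogen), at the same place. The step is expected to be an at least 1.2-fold lower number from compound 3 to compound 4 (0.09 log units; that floor lies within the scatter), set beside an at least 3.0-fold lower number from compound 1 to compound 2 (0.48 log units; beyond the scatter). Compound 3 starts from a limit, so the outcome of compound 4 may itself stay at a limit. Compound 4 is therefore expected near 80000 nM, within 20000 nM to 200000 nM.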

Compound 4, half-maximal inhibitory concentration: 54700 nM
Compound 4: middle estimate off by 1.5-fold (0.17 log units), on the high side; low and high end bracket the measured number.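

In this assay the change from 4-chlorophenyl to benzyl on an aromatic nitrogen gave an at least 1.8-fold lower number from compound 3 to compound 4 (0.26 log units; that floor lies within the scatter) on the core of compound 3, the same direction as on the core of compound 1, although the floor of this new step lies within the scatter. This shows only that the direction held on the two cores shown, and it does not show that the step has the same size on both: the same change on two cores in this assay, an at least 3.0-fold lower number (0.48 log units; beyond the scatter) from compound 1 to compound 2 and an at least 1.8-fold lower number (0.26 log units; that floor lies within the scatter) from compound 3 to compound 4; the limit leaves it open whether they differ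
Neither step has a known true size because compound 1 and compound 3 each sit at a limit of the assay: the limit of > 100000 nM in this assay, at which 2 of the 4 values shown sit.

The compounds shown leave open how phenyl or 4-chlorobenzyl on that aromatic nitrogen would read, which would part the loss of chlorine from the added carbon. They also leave open what an amine on the benzyl ring would do.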